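Urea Aryl Exchange Near the Ceiling of the Assay

The source may report more compounds than this note shows. Statements on the series, on what has been measured and on what is new or still open speak of the compounds shown alone.

The two measured compounds share one core and differ only in the aryl group attached to the urea. In a functional assay on SK-OV-3 cells (Homo sapiens) for inhibition, read by sulforhodamine B assay, with a stated time of 48 h (on this read-out higher numbers stand for lower toxicity in this test and lower numbers for higher toxicity in this test), compound 1 `COc1cc(-c2nn(-c3cccc(NC(=O)Nc4cc(C(F)(F)F)cc(C(F)(F)F)c4)c3)cc2-c2ccncc2)ccc1Cl` gives 15400 nM. Compound 2 `COc1cc(-c2nn(-c3cccc(NC(=O)Nc4ccc(Cl)c(Cl)c4)c3)cc2-c2ccncc2)ccc1Cl` is reported in this assay only as a limit, > 50000 nM, so no number is known for it. Compound 2 therefore stands at the limit of > 50000 nM in this assay, at which 1 of the 2 values shown sits, and the gap between compound 1 and compound 2 cannot be sized from these data. Compound 3 `COc1cc(-c2nn(-c3cccc(NC(=O)Nc4cccc(C(F)(F)F)c4)c3)cc2-c2ccncc2)ccc1Cl` has not yet been measured; it differs from compound 2 by 3-(trifluoromethyl)phenyl in place of 3,4-dichlorophenyl on an amide-type nitrogen. Going by the values given here, no measured step joins two compounds of this set that differ in one place, so the direction of this change is open. The writer expects compound 3 to remain in the upper range of this assay, with a real chance that it too is reported only as a limit. Compound 3 is estimated at 35000 nM, between 12000 nM and 100000 nM. This expectation amounts to a step of an at least 1.4-fold lower number from compound 2 to compound 3 (0.15 log units; that floor lies within the scatter), expected to be modest.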

Compound 3, concentration lethal to 50% of the cells: > 50000 nM
Compound 3 was reported as a limit; the forecaster's own chance of this, stated with the estimate: 45%; middle value at least 1.4-fold (0.15 log units) away from the limit.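

Compound 3 is reported in this assay only as a limit, > 50000 nM. Hydrogen in place of trifluoromethyl on an aromatic carbon gives an at least 3.2-fold higher number from compound 1 to compound 3 (0.51 log units; beyond the scatter), which is the first step in this set that can be read, so the urea aryl group can change the read-out in this test. The step between 3,4-dichlorophenyl and 3-(trifluoromethyl)phenyl on the amide-type nitrogen cannot be read, so these two groups are not told apart, and the two compounds carrying them share one reported limit: the limit of > 50000 nM in this assay, at which 2 of the 3 values shown sit.

The compounds shown leave open whether the lower number of compound 1 depends on trifluoromethyl itself, or whether a chlorine, a methoxy group or a nitrile on the same aromatic carbon would give a similar value. They also leave open how the read-out in this assay would respond to an amine or a carboxylic acid on the urea aryl ring, and where compound 2 and compound 3 stand relative to each other.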